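Lengthening the Acid Chain of a Bicyclic Prostaglandin Analogue

The compounds below may be only part of what the source reports. "The series", "measured", "known", "first", "only" and "open" are said of these compounds alone.

Of the compounds shown here, three have been measured in a functional assay on CHO cells for agonist activity at prostaglandin F2-alpha receptor (Homo sapiens), read by fluorescence and calcium flux; a lower number here means that less compound is needed, a higher number that more compound is needed for the effect. Compound 1 `CS(=O)(=O)NC(=O)CCC/C=C\C[C@@H]1[C@@H](/C=C/[C@@H](O)COc2ccccc2)[C@H](O)C[C@@H]1O` gives 1800 nM. Compound 2 `O=C(O)CCC[C@@H]1CC[C@@H]2[C@@H](/C=C/[C@@H](O)COc3ccccc3)[C@H](O)C[C@@H]2OC1` gives 280 nM, and compound 3 `O=C(O)CCC[C@H]1CC[C@@H]2[C@@H](/C=C/[C@@H](O)COc3ccccc3)[C@H](O)C[C@@H]2OC1` gives 28 nM, the lowest number of the three; compound 2 stands nearest to it and compound 1 furthest from it. Within the data shown here, the only single-point step among the measured compounds is the one from compound 2 to compound 3, which shows a 10-fold lower number from compound 2 to compound 3 (1.00 log units; beyond the scatter) and rests on (the fact that compounds 2 and 3 differ only in the configuration as drawn).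

Compound 4 `O=C(O)CCCC[C@H]1CC[C@@H]2[C@@H](/C=C/[C@@H](O)COc3ccccc3)[C@H](O)C[C@@H]2OC1` has not yet been measured. It differs from compound 3 by carboxymethyl in place of carboxy on a saturated chain carbon, three bonds along the chain from a saturated ring carbon. Among the measured compounds shown here, none of the measured steps bears directly on this kind of change: the one measured step concerns configuration alone, and compound 1 differs from compound 3 in several places at once. The expectation for compound 4 therefore leans on compound 3 by itself, and the range has to be kept wide. A modest rise in the number, beyond the scatter, is expected, a 3.2-fold higher number from compound 3 to compound 4 (0.51 log units; beyond the scatter). Compound 4 is estimated at 90 nM, within a range from 25 nM to 400 nM.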

Compound 4, half-maximal effective concentration: 43 nM
Compound 4: middle estimate off by 2.1-fold (0.32 log units), on the high side; the range from low to high includes it.
By their numbers in this assay, from the lowest: compounds 3 and 4 (each within the scatter of the next); then compound 2; then compound 1.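

Carboxymethyl in place of carboxy on a saturated chain carbon, three bonds along the chain from a saturated ring carbon, gives a 1.5-fold higher number from compound 3 to compound 4 (0.19 log units; within the scatter) and so leaves compound 3 and compound 4 indistinguishable in this measurement. The earlier compounds had shown only that configuration can matter in this series, through a 10-fold lower number from compound 2 to compound 3 (1.00 log units; beyond the scatter); the new step adds that, with the configuration of compound 3 kept, the acid chain accepts this added carbon without a change beyond the scatter. Nothing measured here explains why the step is this small.

The compounds shown leave open whether a still longer chain, or a shorter one, would also stay within the scatter of compound 3, and whether the added carbon would have the same outcome in the configuration of compound 2. Among these compounds, they also leave open whether a primary amide, a methyl ester or a tetrazole could replace the carboxylic acid at the end of this lengthened chain, since the only single-place comparison at this position concerns the chain's length.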